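A few compounds are considered here, and "the series" means these few. Any claim that something is new, unique, unknown or untested is made for them only; others in the source may bear on it.

Working notes on the series.

Compound 1 `CCNCC(=O)Nc1cc(OC)ccc1C(=O)c1ccc(OC)c2c1OC(C)(C)C=C2` is the reference point. In a functional assay on A549 cells (Homo sapiens) for antiproliferative activity, read by MTT assay, with a stated time of 48 h (on this read-out higher numbers stand for weaker inhibition and lower numbers for stronger inhibition), compound 1 gives 1050 nM. Compound 2 `CCNCC(=O)Nc1cc(OC)ccc1C(=O)c1ccc(OC)c2c1C=CC(C)(C)O2` carries a different core; how the two cores differ is not broken down here. In this assay compound 2 gives 2310 nM, the highest number among the three measured compounds, and its value stands beyond the scatter of the other two. Compound 3 `COc1ccc(C(=O)c2ccc(OC)c3c2OC(C)(C)C=C3)c(NC(=O)CN(C)C)c1` shares the core of compound 1 and in this assay compound 3 gives 890 nM.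

Within the data shown here, the one counted change so far is dimethylamino in place of ethylamino on a saturated chain carbon bound to a carbonyl carbon. It made a step of a 1.2-fold lower number from compound 1 to compound 3 (0.07 log units; within the scatter), which is within the scatter, so on the core of compound 1 the exchange of ethylamino for dimethylamino left the read-out essentially unchanged.

Compound 4 `COc1ccc(C(=O)c2ccc(OC)c3c2C=CC(C)(C)O3)c(NC(=O)CN(C)C)c1` has not yet been measured in this assay. Among the measured compounds shown here, it differs from compound 2 by dimethylamino in place of ethylamino on a saturated chain carbon bound to a carbonyl carbon, the same change as the one from compound 1 to compound 3, at the same place and on a saturated chain carbon bound to a carbonyl carbon in both pairs. With a single precedent, on a different core, the expectation for compound 4 rests on that one step only.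

The step from compound 2 to compound 4 in this assay is therefore expected to be a 1.2-fold lower number from compound 2 to compound 4 (0.06 log units; within the scatter), set beside the earlier step because a 1.2-fold lower number from compound 1 to compound 3 (0.07 log units; within the scatter) was within the scatter. For compound 4 in this assay the estimated value is 2000 nM, expected to fall between 900 nM and 4500 nM.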

Compound 4, half-maximal inhibitory concentration: 1850 nM
Compound 4: the middle estimate sits 1.1-fold (0.03 log units) above what was measured; the measured number falls inside the stated range.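

On the core of compound 2, dimethylamino in place of ethylamino on a saturated chain carbon bound to a carbonyl carbon gives a 1.2-fold lower number from compound 2 to compound 4 (0.10 log units; within the scatter) in this assay, so on this core too the exchange leaves the read-out essentially unchanged. This does not show that the exchange would behave the same way on a third core, and it does not show that a change with a step beyond the scatter would carry over equally, since the comparison rests on one exchange on two cores and neither step stands clear of the scatter. Within those limits, the exchange carries from one core to the other in this series without a detectable difference in the size of the step: the same change on two cores in this assay, a 1.2-fold lower number (0.07 log units; within the scatter) from compound 1 to compound 3 and a 1.2-fold lower number (0.10 log units; within the scatter) from compound 2 to compound 4, 1.1-fold (0.02 log units) apart, within the scatter of two such steps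

The compounds shown leave open how far the amine on this chain can be altered on either core, for example with diethylamino or an unsubstituted amino group. They also leave open how a longer chain carrying the same amine, or a carboxylic acid in place of the amine, would read on the two cores.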